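Compound 4 and the loss of piperidin-1-yl

The source may hold more compounds than are shown below. What is called first, only, known or untested is meant among the compounds shown, and "the series" means these compounds.

Compound 1 `O=C(Nc1nc2ccc(Cl)cc2s1)c1cc([N+](=O)[O-])ccc1Cl`: > 27000 nM (a limit)
Compound 2 `Cc1ccc(-c2nc3ccccc3s2)cc1NC(=O)c1cc([N+](=O)[O-])c(N(C)C)cc1Cl`: > 25000 nM (a limit)
Compound 3 `Cc1ccc(-c2nc3ccccc3s2)cc1NC(=O)c1cc([N+](=O)[O-])c(N2CCCCC2)cc1Cl`: > 25000 nM (a limit)

All three entries come from an ADME assay on BJ cells (Homo sapiens) for cytotoxicity, with a stated time of 72 h (on this read-out higher numbers stand for an effect only at larger amounts of compound and lower numbers for an effect already at smaller amounts), and none of them is an exact number. Compound 3 stands at the limit of > 25000 nM in this assay, at which 2 of the 3 values shown sit. Compound 1 stands at the limit of > 27000 nM in this assay, at which 1 of the 3 values shown sits.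

Compound 4 `Cc1ccc(-c2nc3ccccc3s2)cc1NC(=O)c1cc([N+](=O)[O-])ccc1Cl` has hydrogen in place of piperidin-1-yl on an aromatic carbon, ortho to a nitro group: hydrogen in place of piperidin-1-yl on an aromatic carbon.

For the measured compounds named here, only one measured step bears on this place, a step that the two limits leave unreadable from compound 2 to compound 3, where piperidin-1-yl took the place of dimethylamino on an aromatic carbon. That step has no readable size, so it gives neither a magnitude nor a direction. Compound 1 also carries hydrogen at this place, and its result is the limit > 27000 nM. No step beyond the scatter is therefore expected in this assay, in either direction, and a result reported only as a limit is likely. The expected step is a number no higher from compound 3 to compound 4 (the limit leaves the size open). Compound 4 is estimated at 25000 nM, with an expected range from 9000 nM to 50000 nM.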

Compound 4, half-maximal effective concentration: > 14000 nM
Compound 4: no number, only a limit (the forecaster's own chance of this, stated with the estimate: 75%); the middle value is on the limit's open side.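

For the compounds shown here, compound 2, compound 3 and compound 4 are each reported only as a limit in this assay, and no step among them can be read. The compounds shown leave open whether hydrogen, dimethylamino or piperidin-1-yl at this place changes the read-out at all, and in which direction.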